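The source may hold more compounds than are shown below. What is called first, only, known or untested is meant among the compounds shown, and "the series" means these compounds.

Of the compounds shown here, three of one study have been measured in a functional assay on Huh-7 cells (Homo sapiens) for antiproliferative activity, with a stated time of 48 h; a lower number here means a stronger inhibitor, a higher number a weaker inhibitor. Compound 1 `CCN(CC)c1ccc(-c2cccc(C#N)c2)nn1` gives there only a limit, > 25000 nM. Compound 2 `CCN(CC)c1ccc(-c2ccc(C#N)cc2)nn1` likewise gives only a limit, > 25000 nM. Both values sit at the limit of > 25000 nM in this assay, at which 2 of the 3 values shown sit. The difference between the cores of compound 1 and compound 2 is not broken down here. Compound 3 `CCOC(=O)c1ccc(-c2ccc(N(CC)CC)nn2)cc1` gives 9000 nM in this assay. The change ethoxycarbonyl in place of cyano on an aromatic carbon makes the step of an at least 2.7-fold lower number from compound 2 to compound 3 (0.44 log units; beyond the scatter).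

Compound 4 `CCOC(=O)c1cccc(-c2ccc(N(CC)CC)nn2)c1` is not yet measured. From compound 1 it is the same kind of change, (ethoxycarbonyl in place of cyano on an aromatic carbon), though here the group sits meta to a large group, whereas in compound 3 it sits para to a large group. Compound 1 stands at a limit, so the step can only be set beside an at least 2.7-fold lower number from compound 2 to compound 3 (0.44 log units; beyond the scatter) in size. For compound 4 a step of an at least 1.6-fold lower number from compound 1 to compound 4 (0.22 log units; that floor lies within the scatter) is expected. Compound 4 is estimated in this assay at 15000 nM, between 5000 nM and 40000 nM.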

Compound 4, half-maximal inhibitory concentration: > 25000 nM
Compound 4 was reported as a limit; the forecaster's own chance of this, stated with the estimate: 40%; middle value at least 1.6-fold (0.22 log units) away from the limit.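

No step can be read from compound 1 to compound 4, since each gives only a limit: the limit of > 25000 nM in this assay, at which 3 of the 4 values shown sit. From the compounds shown here alone, whether ethoxycarbonyl in place of cyano, meta to a large group, changes the number in this assay at all stays open.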